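The compounds below may be only part of what the source reports. "The series", "measured", "known", "first", "only" and "open" are said of these compounds alone.

Measured so far:

Compound 1, `CN1C[C@@H](c2ccccc2)[C@@]2(Cc3ccccc3C2=O)[C@@]12C(=O)Nc1ccccc12`, gives 42.5% in a functional assay on the whole organism (strain Wister albino) for inhibition, with Rattus norvegicus as the target, read by paw edema, with stated times of 1 h and 3 h, at a dose of 50 mg/kg by the intraperitoneal route; on this read-out lower numbers stand for less inhibition and higher numbers for more inhibition at the one dose given (going by the name of the read-out).
Compound 2, `CN1C(=O)[C@@]2(c3ccccc31)N(C)C[C@@H](c1ccco1)[C@@]21Cc2ccccc2C1=O`, gives 17.5% in this assay.
Compound 3, `CN1C(=O)[C@@]2(c3ccccc31)N(C)C[C@@H](c1ccc(Cl)cc1)[C@@]21Cc2ccccc2C1=O`, gives 9.4% in this assay.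

Among these three numbers compound 2 stands second highest. Its nearest neighbour is compound 3, separated by a step of a number 8.1 percentage points lower from compound 2 to compound 3 (within the scatter), which lies within the scatter of this kind of measurement. Its furthest neighbour is compound 1, whose value lies above that of compound 2 by a margin beyond the scatter.

The unmeasured compound 4, `COc1ccc([C@@H]2CN(C)[C@]3(C(=O)N(C)c4ccccc43)[C@]23Cc2ccccc2C3=O)cc1`, differs from compound 2 in one place: 4-methoxyphenyl in place of furan-2-yl on a saturated ring carbon. Going by the values given here, the only measured step that bears on this change is the one from compound 2 to compound 3, where a six-membered carbon-only aromatic ring likewise replaced the furan-2-yl group on the same saturated ring carbon; that step was a number 8.1 percentage points lower from compound 2 to compound 3 (within the scatter) and stayed within the scatter. Among the compounds with values here, no step involving a 4-methoxyphenyl group has been measured, so nothing more specific can be drawn.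

On this basis compound 4 is expected to show in this assay no step beyond the scatter from compound 2, amounting to an estimated a number 3.5 percentage points lower from compound 2 to compound 4 (within the scatter). The estimate for compound 4 is 14%, with a range from 4% to 30%.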

Compound 4, a percentage reported as inhibition, in the whole organism at one dose (the size of the read-out at that dose, not a potency): 3.3%
The estimate for compound 4 lay 10.7 percentage points above the measured number; measured number outside the range, below it.
By their numbers in this assay, from the lowest: compounds 4, 3 and 2 (each within the scatter of the next, the first and the last beyond it); then compound 1.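

In this assay, 4-methoxyphenyl in place of furan-2-yl on the saturated ring carbon gives a number 14.2 percentage points lower from compound 2 to compound 4 (beyond the scatter), so a replacement at this position now produces a modest loss of inhibition beyond the scatter, which the earlier 4-chlorophenyl replacement, at a number 8.1 percentage points lower from compound 2 to compound 3 (within the scatter), did not show. The two groups bearing a six-membered aromatic ring of carbon only cannot be told apart, since methoxy in place of chloro on an aromatic carbon gives a number 6.1 percentage points lower from compound 3 to compound 4 (within the scatter). Nothing available explains why the 4-methoxyphenyl step passes the scatter, and no measured property of these groups bears on it.

Compound 1, at 42.5%, differs from compound 2 in more than one place, so its higher number cannot be assigned to the group at this carbon or to any other single change in the core. As far as these compounds go, it also remains open whether an amine or a carboxylic acid on the aromatic ring at this position, or a longer alkoxy chain in place of methoxy, would bring the inhibition back up or leave it as low as in compound 4.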